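Benzyl to allyl in a series held at the limit

The source may hold more compounds than are shown below. What is called first, only, known or untested is meant among the compounds shown, and "the series" means these compounds.

Measured in a functional assay on HeLa cells (Homo sapiens) for antiproliferative activity, read by sulforhodamine B assay; a higher number here means a weaker inhibitor of growth, a lower number a stronger inhibitor of growth:
- compound 1 `C[C@@H]1O[C@H](COCc2ccccc2)[C@@H](OCc2ccccc2)[C@H](OCc2ccccc2)C1=O`: > 50000 nM
- compound 2 `CCC[C@@H]1O[C@H](COCc2ccccc2)[C@@H](OCc2ccccc2)[C@H](OCc2ccccc2)C1=O`: > 50000 nM
- compound 3 `O=C1[C@H](Cc2ccccc2)O[C@H](COCc2ccccc2)[C@@H](OCc2ccccc2)[C@@H]1OCc1ccccc1`: > 50000 nM

Each entry is a limit of the assay and not a number. Compound 3 therefore has no position of its own within the series, and the same holds for the other two compounds. The whole set rests on (the limit of > 50000 nM in this assay, at which 3 of the 3 values shown sit).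

Compound 4 `C=CC[C@@H]1O[C@H](COCc2ccccc2)[C@@H](OCc2ccccc2)[C@H](OCc2ccccc2)C1=O` differs from compound 3 in one place: vinyl in place of phenyl on a saturated chain carbon bound to a saturated ring carbon, or benzyl to allyl when cut one bond further out. The counted difference is vinyl in place of phenyl on a saturated chain carbon bound to a saturated ring carbon.

Among the measured compounds shown here, three measured steps bear on this place: a step that the two limits leave unreadable from compound 1 to compound 2, a step that the two limits leave unreadable from compound 1 to compound 3 and a step that the two limits leave unreadable from compound 2 to compound 3. None of them has a readable size, so they give no trend to carry over. The expectation rests only on compound 1, compound 2 and compound 3 sharing one limit, and no step beyond the scatter is expected in this assay, in either direction. The estimated step is a number no higher from compound 3 to compound 4 (the limit leaves the size open). For compound 4 the expected value is 50000 nM, with an estimated range of 15000 nM to 100000 nM, and a report of a limit alone is the likeliest outcome.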

Compound 4, concentration for 50% growth inhibition: > 50000 nM
Compound 4 was reported as a limit (the forecaster's own chance of this, stated with the estimate: 80%); the middle value sits exactly at the limit.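

Compound 4 gives > 50000 nM, which is a limit and not a number, so no step to compound 1, compound 2 or compound 3 can be read, and the series still rests on one limit: the limit of > 50000 nM in this assay, at which 4 of the 4 values shown sit.

The compounds shown leave open what true value lies behind each limit, and whether hydrogen, ethyl, phenyl or vinyl at this place changes growth inhibition at all.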